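This account rests on a few compounds, and the source may have more. Where it says the series, first, only, none or still open, it means among the compounds named here.

Among the measured compounds shown here, in an in vivo functional assay on the whole organism (MDA-MB-435 cells, Homo sapiens) for antiproliferative activity (a higher number here means a weaker inhibitor, a lower number a stronger inhibitor), compound 1 `CO[C@@H](C(=O)NC1CC[C@@H](OC(=O)c2ccccc2)CNC1=O)[C@H](O)[C@@H](O)[C@H](O)/C=C/C(C)(C)C` gives 370 nM, the highest number of the three compounds measured so far. Compound 2 `CCCCCc1ccc(C(=O)O[C@@H]2CCC(NC(=O)[C@H](OC)[C@H](O)[C@@H](O)[C@H](O)/C=C/C(C)(C)C)C(=O)NC2)cc1` gives 20 nM, and compound 3 `CO[C@@H](C(=O)NC1CC[C@@H](OC(=O)CC2CCCCC2)CNC1=O)[C@H](O)[C@@H](O)[C@H](O)/C=C/C(C)(C)C` gives 60 nM. Compound 4 `CO[C@@H](C(=O)NC1CC[C@@H](OC(=O)C2CCCC2)CNC1=O)[C@H](O)[C@@H](O)[C@H](O)/C=C/C(C)(C)C` has not yet been measured. It keeps the core of compound 1 but carries cyclopentyl in place of phenyl on a carbonyl carbon.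

For the measured compounds named here, the closest precedent is the swap of phenyl for cyclohexylmethyl on a carbonyl carbon, which gave a 6.2-fold lower number from compound 1 to compound 3 (0.79 log units; beyond the scatter). It also replaces the aromatic ring with a non-aromatic one. The step of a 19-fold lower number from compound 1 to compound 2 (1.27 log units; beyond the scatter) bears less directly, since pentyl is added to the aromatic ring and that ring stays. Going by the values given here, no measured compound carries cyclopentyl itself, so the precedent is only a guide. A modest step to a lower number is therefore expected in this assay, an estimated 2.8-fold lower number from compound 1 to compound 4 (0.45 log units; beyond the scatter). For compound 4 the expected value is 130 nM, with an estimated range from 45 nM to 350 nM.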

Compound 4, half-maximal inhibitory concentration: 130 nM
The estimate for compound 4 equals the measured number at the digits printed; measured number inside the range.
By their numbers in this assay, from the lowest: compound 2; then compound 3; then compound 4; then compound 1.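

In this assay, replacing phenyl with cyclopentyl on this carbonyl carbon gives a 2.8-fold lower number from compound 1 to compound 4 (0.45 log units; beyond the scatter), so within these compounds an aromatic ring is not required here, although compound 2, which keeps one, has the lowest number. The other two steps, a 2.2-fold higher number from compound 3 to compound 4 (0.34 log units; beyond the scatter) and a 6.5-fold higher number from compound 2 to compound 4 (0.81 log units; beyond the scatter), show that cyclopentyl does not match cyclohexylmethyl or 4-pentylphenyl, while heavy-atom count alone cannot order the series, as cyclopentyl has fewer heavy atoms than phenyl yet compound 4 has the lower number. No measurement shown here explains these differences.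

Going by these compounds, it remains open how cyclohexyl attached directly to the carbonyl carbon would compare with cyclopentyl. A straight pentyl chain in the same place, with no ring, would show whether a ring is needed at all.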